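Thiourea series on the shared core: bromo to trifluoromethyl

This account rests on a few compounds, and the source may have more. Where it says the series, first, only, none or still open, it means among the compounds named here.

Compound 3 `NC(=O)c1c(NC(=O)c2ccccc2Cl)sc2c1CCN(C(=S)Nc1ccccc1Br)C2` gives 9090 nM in a functional assay on HL-60 cells (Homo sapiens) for antiproliferative activity, with a stated time of 24 h; a higher number here means a weaker inhibitor, a lower number a stronger inhibitor. It stands second highest of the three numbers: the step of a 2.5-fold lower number from compound 1 to compound 3 (0.39 log units; beyond the scatter) from compound 1 `NC(=O)c1c(NC(=O)c2ccccc2Cl)sc2c1CCN(Cc1ccc(Cl)cc1)C2` with 22500 nM lies beyond the scatter, while the step of a 1.5-fold higher number from compound 2 to compound 3 (0.18 log units; within the scatter) from compound 2 `NC(=O)c1c(NC(=O)c2ccccc2Cl)sc2c1CCN(C(=S)Nc1ccccc1)C2` with 5940 nM lies within it. Compound 4 `NC(=O)c1c(NC(=O)c2ccccc2Cl)sc2c1CCN(C(=S)Nc1ccccc1C(F)(F)F)C2` carries the change (trifluoromethyl in place of bromo on an aromatic carbon). Among the compounds with values here, the only measured step at this position, a 1.5-fold higher number from compound 2 to compound 3 (0.18 log units; within the scatter), is within the scatter; no step exchanges one substituent for another there. The expectation for a 1.1-fold lower number from compound 3 to compound 4 (0.06 log units; within the scatter) is therefore no step beyond the scatter, in either direction. Compound 4 is expected to give about 8000 nM in this assay, in a range from 3000 nM to 20000 nM.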

Compound 4, half-maximal inhibitory concentration: 10600 nM
For compound 4 the middle estimate is 1.3-fold (0.12 log units) below the measured one, within the range that was stated.
By their numbers in this assay, from the lowest: compounds 2, 3 and 4 (each within the scatter of the next); then compound 1.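

Within the data shown here, the first exchange of one substituent for another at this position gives a 1.2-fold higher number from compound 3 to compound 4 (0.07 log units; within the scatter), and the step from the unsubstituted ring, a 1.8-fold higher number from compound 2 to compound 4 (0.25 log units; within the scatter), also stays inside the scatter. Hydrogen, bromo and trifluoromethyl on this aromatic carbon are therefore not separated in this assay, so the position has so far tolerated all three without a readable change. No available measurement bears on this result. Open, from the compounds shown here alone, is whether an amine or a carboxylic acid on the same aromatic carbon would give a step beyond the scatter.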